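The compounds below may be only part of what the source reports. "The series", "measured", "known", "first", "only" and "open" are said of these compounds alone.

Compound 1 `CC(C)(C)C[C@@H](O)C(=O)N1N=CC[C@H]1C(=O)NCc1cc(Cl)ccc1-n1cnnn1` gives 590 nM in a functional assay on a cell-free system (plasma, Homo sapiens), with a stated time of 3 min; on this read-out lower numbers stand for stronger inhibition and higher numbers for weaker inhibition. Compound 2 `CC(C)(C)[C@@H](O)C(=O)N1N=CC[C@H]1C(=O)NCc1cc(Cl)ccc1-n1cnnn1` carries the change tert-butyl in place of neopentyl on a saturated chain carbon bound to a carbonyl carbon and an oxygen on a saturated carbon and in this assay compound 2 gives 1400 nM; the change produced a 2.4-fold higher number from compound 1 to compound 2 (0.38 log units; beyond the scatter). Compound 3 `CC(C)(C)C[C@@H](O)C(=O)N1[C@@H]2C[C@@H]2C[C@H]1C(=O)NCc1cc(Cl)ccc1-n1cnnn1` stands on a different core, and the difference between the two cores is not broken down here. In this assay compound 3 gives 520 nM, a number that lies within the scatter of the number of compound 1. Compound 4 `CC(C)(C)[C@@H](O)C(=O)N1[C@@H]2C[C@@H]2C[C@H]1C(=O)NCc1cc(Cl)ccc1-n1cnnn1` has not yet been measured; it carries the same change on the core of compound 3: tert-butyl in place of neopentyl on a saturated chain carbon bound to a carbonyl carbon and an oxygen on a saturated carbon. Because the same change gave a 2.4-fold higher number from compound 1 to compound 2 (0.38 log units; beyond the scatter), a step of similar size is expected here, a 2.4-fold higher number from compound 3 to compound 4 (0.38 log units; beyond the scatter). The number of compound 4 in this assay is therefore estimated at 1250 nM, likely between 600 nM and 2600 nM.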

Compound 4, half-maximal inhibitory concentration: 1100 nM
Compound 4: the middle estimate sits 1.1-fold (0.06 log units) above what was measured, within the range that was stated.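

On the core of compound 3, tert-butyl in place of neopentyl gave a 2.1-fold higher number from compound 3 to compound 4 (0.33 log units; beyond the scatter) in this assay, the same direction as on the core of compound 1. The two steps do not differ in size: the same change on two cores in this assay, a 2.4-fold higher number (0.38 log units; beyond the scatter) from compound 1 to compound 2 and a 2.1-fold higher number (0.33 log units; beyond the scatter) from compound 3 to compound 4, 1.1-fold (0.05 log units) apart, within the scatter of two such steps. Within the data shown here, this shows that the change carried over between these two cores in this one read-out, but with only two pairs it does not show that it would carry to any other core, nor why the step arises.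

The compounds shown leave open what a chain longer than neopentyl would do at this place. They also leave open whether an amine on that chain would give a different number on either core.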